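Solubility notes: moving from compound 3 to compound 4

The source may report more compounds than this note shows. Statements on the series, on what has been measured and on what is new or still open speak of the compounds shown alone.

Measured compounds and values:
compound 1 `COc1ccc(F)cc1CNCCCNc1ccnc2cc(C3CCCCC3)ccc12` — 4200 nM
compound 2 `COc1cccc(Oc2ccc3c(NCCCNCc4cc(F)ccc4OC)ccnc3c2)c1` — 14500 nM
compound 3 `COc1ccc(F)cc1CNCCCNc1ccnc2cc(Cc3ccccc3)ccc12` — 4200 nM

In a physicochemical assay for solubility, with a stated time of 18 h, at pH 7.4 (a higher number here means a more soluble compound, a lower number a less soluble compound), compound 3 gives 4200 nM. It stands level with compound 1 no change at the digits printed from compound 1 to compound 3 (within the scatter), the two together forming the low end of the three numbers, while compound 2 sits above a 3.5-fold lower number from compound 2 to compound 3 (0.54 log units; beyond the scatter). Compound 4 `COc1ccc(F)cc1CNCCCNc1ccnc2cc(-c3ccc(C(F)(F)F)cc3)ccc12` is the next variation at the same aromatic carbon: 4-(trifluoromethyl)phenyl in place of benzyl on an aromatic carbon.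

Within the data shown here, no measured step replaces benzyl by a trifluoromethyl-bearing phenyl, so the bearing is indirect. The steps at this carbon are a 3.5-fold higher number from compound 1 to compound 2 (0.54 log units; beyond the scatter), no change at the digits printed from compound 1 to compound 3 (within the scatter) and a 3.5-fold lower number from compound 2 to compound 3 (0.54 log units; beyond the scatter): a modest rise appears only with 3-methoxyphenoxy, whereas cyclohexyl and benzyl give the same number. A ring without an ether oxygen entering in place of benzyl is therefore expected to leave the value near that of compound 3, with at most a small step down, not clearly beyond the scatter.

Compound 4 is expected to give about 2800 nM in this assay, estimated range 1000 nM to 7000 nM. The expected step is a 1.5-fold lower number from compound 3 to compound 4 (0.18 log units; within the scatter).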

Compound 4, solubility: 32000 nM
For compound 4 the middle estimate is 11-fold (1.06 log units) below the measured one; the whole stated range lies below it.
By their numbers in this assay, from the lowest: compounds 1 and 3 (each within the scatter of the next); then compound 2; then compound 4.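

In this assay the 4-(trifluoromethyl)phenyl group gives the highest number at this aromatic carbon, above both benzyl (a 7.6-fold higher number from compound 3 to compound 4 (0.88 log units; beyond the scatter)) and cyclohexyl (a 7.6-fold higher number from compound 1 to compound 4 (0.88 log units; beyond the scatter)), and also above 3-methoxyphenoxy (a 2.2-fold higher number from compound 2 to compound 4 (0.34 log units; beyond the scatter)). A rise at this position therefore does not depend on an ether oxygen, which 3-methoxyphenoxy carries and 4-(trifluoromethyl)phenyl lacks, and the level shared by compound 1 and compound 3 is not a floor for every carbon-only ring placed here. Nothing measured on these compounds explains the rise.

From the compounds shown here alone, whether the rise belongs to the trifluoromethyl group or to the phenyl ring itself remains open, and unsubstituted phenyl or 4-methoxyphenyl at this carbon would separate the two. Going by these compounds, how an amine or a carboxylic acid on that ring would read also remains unknown.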